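The source may hold more compounds than are shown below. What is called first, only, known or untested is meant among the compounds shown, and "the series" means these compounds.

Measured so far in a functional assay on the whole organism for inhibition, with Rattus norvegicus as the target, read by paw edema, with stated times of 1 h and 3 h, at a dose of 50 mg/kg by the oral route; a lower number here means less inhibition, a higher number more inhibition at the dose given (going by the name of the read-out):
- compound 1 `C/C(=N\OCC(=O)O)c1ccc(C(C)(C)C)cc1` gives < 20% in this assay, a limit of the assay rather than a number.
- compound 2 `C/C(=N\OCC(=O)O)c1ccc(C#N)cc1` gives < 20% in this assay, likewise a limit and not a number.

Compound 2 therefore stands at the floor of this assay, as the limit of < 20% in this assay, at which 2 of the 2 values shown sit, records; how far under that floor it lies is not known. For the measured compounds named here, the only step measured between compounds differing in one place is a step that the two limits leave unreadable from compound 1 to compound 2, and its size cannot be read because the limit of < 20% in this assay, at which 2 of the 2 values shown sit, covers both of its ends. It shows only that swapping tert-butyl for cyano did not lift inhibition out of the limit region.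

The next compound, compound 3 `C/C(=N\OCC(=O)O)c1ccc(O)cc1`, differs from compound 2 at one place: hydroxy in place of cyano on an aromatic carbon. Going by the values given here, no measured step bears directly on this change, and the one known step is unreadable in size, so the expectation rests on where compound 2 itself stands. Compound 3 is expected to give 10% in this assay, estimated to fall within 0% to 25%, most likely once more as a limit. The step that the limit leaves unreadable from compound 2 to compound 3 that this estimate implies is expected to stay within the scatter.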

Compound 3, a percentage reported as inhibition, in the whole organism at one dose (the size of the read-out at that dose, not a potency): < 20%
Compound 3 was reported as a limit (the forecaster's own chance of this, stated with the estimate: 80%); the middle value does not contradict the limit.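

No new step can be read: the steps joining compound 3 to compound 2 and to compound 1 have a limit at both ends, so their sizes stay unknown, because all three compounds sit at the same floor: the limit of < 20% in this assay, at which 3 of the 3 values shown sit.

The compounds shown leave open how far each lies under that limit in this assay, and whether any group on this aromatic carbon can lift inhibition clear of it.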